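The compounds below may be only part of what the source reports. "The series", "measured", "known", "first", "only" and "open" are said of these compounds alone.

Compound 2, the structure `Fc1ccc(C2CC(c3ccc(Cl)s3)=NN2c2nc(-c3ccc(Br)cc3)cs2)cc1`, was tested in an ADME assay on NIH3T3 cells (Mus musculus) for cytotoxicity, read by XTT assay, with a stated time of 24 h (on this read-out higher numbers stand for weaker inhibition and lower numbers for stronger inhibition), where compound 2 gives > 500 ug/mL, which is a limit of the assay and not a number. Compound 1, the structure `Fc1ccc(C2CC(c3ccc(Cl)s3)=NN2c2nc(-c3ccc(C(F)(F)F)cc3)cs2)cc1`, differs from it only in carrying trifluoromethyl where compound 2 carries bromo, and in this assay compound 1 gives > 500 ug/mL, also a limit. Among the measured compounds shown here, the step from compound 1 to compound 2 therefore reads a step that the two limits leave unreadable from compound 1 to compound 2, and the only evidence on the measured side is the limit of > 500 ug/mL in this assay, at which 2 of the 2 values shown sit. Compound 3, the structure `N#Cc1ccc(-c2csc(N3N=C(c4ccc(Cl)s4)CC3c3ccc(F)cc3)n2)cc1`, is the next member of the set and differs from compound 2 by cyano in place of bromo on an aromatic carbon. For the measured compounds named here, the one measured step, a step that the two limits leave unreadable from compound 1 to compound 2, gives no readable size, so nothing suggests any step beyond the scatter for this change. Compound 3 is therefore expected to sit again at the limit in this assay, estimated at 500 ug/mL with a range from 200 ug/mL to 1200 ug/mL. The step from compound 2 to compound 3 that this estimate means is a number no higher from compound 2 to compound 3 (the limit leaves the size open), expected to be none beyond the scatter.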

Compound 3, half-maximal inhibitory concentration: > 500 ug/mL
Compound 3: only a limit was reported; the forecaster's own chance of this, stated with the estimate: 85%; the middle value lies on the limit itself.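

No step among compound 1, compound 2 and compound 3 can be read in this assay, as all three results are limits of the assay and not numbers: the limit of > 500 ug/mL in this assay, at which 3 of the 3 values shown sit.

The compounds shown leave open whether trifluoromethyl, bromo and cyano differ at all in this read-out, and at what concentration any of the three would reach half-maximal inhibition.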